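Ethoxy for Trifluoromethoxy on a Bile Acid Receptor Amide

A few compounds are considered here, and "the series" means these few. Any claim that something is new, unique, unknown or untested is made for them only; others in the source may bear on it.

Within the data shown here, compound 2 `CS(=O)(=O)Nc1ccc(CNC(=O)c2ccc(OC(F)(F)F)cc2)c(Cl)c1` is one of two compounds measured so far. In an assay on HeLa cells for agonist activity at Bile acid receptor (Homo sapiens), read by a luciferase reporter, with a stated time of 24 h (on this read-out lower numbers stand for an effect already at smaller amounts and higher numbers for an effect only at larger amounts of compound), compound 2 gives 1090 nM. Among the measured compounds shown here, its only measured neighbour is compound 1 `CN(C)c1ccc(C(=O)NCc2ccc(NS(C)(=O)=O)cc2Cl)cc1`, which in this assay gives 1460 nM; the two numbers sit within the scatter of each other, as the step of a 1.3-fold lower number from compound 1 to compound 2 (0.13 log units; within the scatter) shows. Compound 3 `CCOc1ccc(C(=O)NCc2ccc(NS(C)(=O)=O)cc2Cl)cc1` is not yet measured. It differs from compound 2 in one place: ethyl in place of trifluoromethyl on an oxygen on an aromatic ring. For the measured compounds named here, no measured step bears on this exchange at the oxygen; the one step known, from compound 1 to compound 2, concerns a different group on that ring and was within the scatter. With nothing pointing either way, compound 3 is expected to stay close to compound 2, a step of a 1.2-fold higher number from compound 2 to compound 3 (0.08 log units; within the scatter). The estimate for compound 3 in this assay is therefore 1300 nM, with a range from 500 nM to 3500 nM.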

Compound 3, half-maximal effective concentration: 2200 nM
Compound 3: middle estimate off by 1.7-fold (0.23 log units), on the low side; the measured number falls inside the stated range.
By their numbers in this assay, from the lowest: compounds 2, 1 and 3 (each within the scatter of the next).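

Among these compounds, this is the first exchange at the oxygen on an aromatic ring to be seen in this assay: ethyl in place of trifluoromethyl gives (a 2.0-fold higher number from compound 2 to compound 3 (0.30 log units; within the scatter)), a step still printed as within the scatter. Compound 3 also allows a second comparison on the aromatic carbon, ethoxy in place of dimethylamino, which gives (a 1.5-fold higher number from compound 1 to compound 3 (0.18 log units; within the scatter)). Trifluoromethoxy, dimethylamino and ethoxy at this place, in compound 2, compound 1 and compound 3, thus all stand within the scatter of one another.

Open, as far as these compounds go, is whether any group here would carry the number beyond the scatter, for instance a longer alkyl chain on the oxygen, a free hydroxyl, or a carboxylic acid on the aromatic carbon. Nothing available accounts for the size of either step.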